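Amino substituent variation on the shared core

The source may hold more compounds than are shown below. What is called first, only, known or untested is meant among the compounds shown, and "the series" means these compounds.

Measured compounds in a functional assay on HEK293 cells for antagonist activity at transient receptor potential cation channel subfamily V member 1 (Homo sapiens), read by calcium flux; a lower number here means a stronger inhibitor, a higher number a weaker inhibitor:
- compound 1 `FC(F)(F)c1ccc(Nc2ncnc3sc(Nc4c(Cl)cccc4Cl)nc23)cc1`: 12 nM
- compound 2 `FC(F)(F)c1ccc(Nc2nc(N3CCCC3)nc3sc(Nc4c(Cl)cccc4Cl)nc23)cc1`: 12 nM
- compound 3 `CN(C)c1nc(Nc2ccc(C(F)(F)F)cc2)c2nc(Nc3c(Cl)cccc3Cl)sc2n1`: 59 nM

Compound 3 carries the highest number of the three in this assay. Its nearest neighbour is compound 1, as the step of a 4.9-fold higher number from compound 1 to compound 3 (0.69 log units; beyond the scatter) shows, and the step of a 4.9-fold higher number from compound 2 to compound 3 (0.69 log units; beyond the scatter) is of the same size; compound 1 and compound 2 themselves differ by no change at the digits printed from compound 1 to compound 2 (within the scatter).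

Compound 4 `CCN(CC)c1nc(Nc2ccc(C(F)(F)F)cc2)c2nc(Nc3c(Cl)cccc3Cl)sc2n1` differs from compound 3 in one place: diethylamino in place of dimethylamino on an aromatic carbon. For the measured compounds named here, the steps that bear on this are a 4.9-fold higher number from compound 1 to compound 3 (0.69 log units; beyond the scatter) and a 4.9-fold higher number from compound 2 to compound 3 (0.69 log units; beyond the scatter), both modest and both beyond the scatter, showing that dimethylamino gave a higher number than either hydrogen or pyrrolidin-1-yl at this carbon. Going by the values given here, no measured step replaces dimethylamino by diethylamino, so the direction is uncertain; a return towards the numbers of compound 1 and compound 2 is plausible, but so is no change beyond the scatter. Compound 4 is therefore expected to give about 35 nM in this assay, with a range of 12 nM to 100 nM. This estimate corresponds to a step of a 1.7-fold lower number from compound 3 to compound 4 (0.23 log units; within the scatter).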

Compound 4, half-maximal inhibitory concentration: 48 nM
Compound 4: middle estimate off by 1.4-fold (0.14 log units), on the low side, within the range that was stated.
By their numbers in this assay, from the lowest: compounds 1 and 2 (each within the scatter of the next); then compounds 4 and 3 (each within the scatter of the next).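

In this assay the step of a 1.2-fold lower number from compound 3 to compound 4 (0.09 log units; within the scatter) leaves diethylamino and dimethylamino within the scatter of each other at this carbon between two ring nitrogen atoms. The steps of a 4.0-fold higher number from compound 2 to compound 4 (0.60 log units; beyond the scatter) and a 4.0-fold higher number from compound 1 to compound 4 (0.60 log units; beyond the scatter) show that diethylamino, like dimethylamino, stands apart from pyrrolidin-1-yl and from hydrogen, so across these four compounds the two amino groups with no ring share the higher numbers, and no compound shown goes against this. No measurement to hand accounts for this separation.

Open, going by these compounds, is whether the low number of compound 2 extends to other cyclic amines such as piperidine or morpholine, or to the larger azepane. Also open, on these data alone, is how a secondary amine such as methylamino, or a single longer chain such as n-propyl, would read at this carbon.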